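Dropping the Nitro Group from Compound 3

The compounds below may be only part of what the source reports. "The series", "measured", "known", "first", "only" and "open" are said of these compounds alone.

Of the compounds shown here, three have been measured in a functional assay for inhibition, read by spectrophotometry, with a stated time of 20 min, tested at 4 mg/mL; on this read-out lower numbers stand for a weaker effect and higher numbers for a stronger effect at the one concentration tested. Compound 1, `CCC(C)C(C(=O)Nc1ccc(C(C)=O)cc1)N(C(=O)c1ccccc1)S(=O)(=O)c1ccc(C)cc1`, gives 41.1%, and compound 2, `CC(=O)c1ccc(NC(=O)C(C(C)C)N(C(=O)c2ccccc2)S(=O)(=O)c2ccc(C)cc2)cc1`, gives 36.6%. Between them lies one change, hydrogen in place of methyl on a saturated chain carbon, and that step, a number 4.5 percentage points lower from compound 1 to compound 2 (within the scatter), changes little. Compound 3, `CC(=O)c1ccc(NC(=O)C2CCCN2S(=O)(=O)c2ccc([N+](=O)[O-])cc2)cc1`, gives 25.3%, which is the lowest of the three numbers, standing beyond the scatter below both compound 2 and compound 1.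

Compound 4, `CC(=O)c1ccc(NC(=O)C2CCCN2S(=O)(=O)c2ccccc2)cc1`, has not been measured. It differs from compound 3 in one place: hydrogen in place of nitro on an aromatic carbon. Among the measured compounds shown here, the only step measured so far, from compound 1 to compound 2, concerns a methyl on a saturated chain and says nothing about a nitro on an aromatic ring, so there is no measured step that bears on this change. The expectation therefore rests on compound 3 alone, and the step is estimated as a number 3.3 percentage points lower from compound 3 to compound 4 (within the scatter), which is no change beyond the scatter in this assay, with a wide range around it. Compound 4 is thus expected to give about 22%, with the estimate running from 6% to 38%.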

Compound 4, a percentage reported as inhibition, at one concentration (the size of the read-out at that concentration, not a potency): 33.4%
Compound 4: the middle estimate sits 11.4 percentage points below what was measured; the range from low to high includes it.
By their numbers in this assay, from the lowest: compounds 3, 4, 2 and 1 (each within the scatter of the next, the first and the last beyond it).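

In this assay, the 4-nitrophenyl to phenyl change gives a number 8.1 percentage points higher from compound 3 to compound 4 (within the scatter), so at this place, para to a large group on the aromatic ring, replacing nitro with hydrogen leaves the two compounds inside the usual spread of repeated measurements. Among the compounds shown here, this is the first measured step on the aromatic ring in this set, as the earlier step concerned a methyl on a saturated chain, and it gives no sign that the nitro group is required for the effect seen at the one concentration tested. No supporting data bear on this step, so its size stays without an explanation.

The compounds shown compare only hydrogen and nitro at this place, and they leave open how an amine, a carboxylic acid or a methoxy group would read there. Also open, going by these compounds, is whether the same change would give a similar step on the core of compound 2, and whether two compounds that read alike at a single concentration would also match in potency.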